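This account rests on a few compounds, and the source may have more. Where it says the series, first, only, none or still open, it means among the compounds named here.

Compound 3 `CC(C)(C)Cc1c(-c2cccnc2)sc(N)c1C(=O)c1ccc(Cl)cc1` belongs to a small set of three close analogues. In an assay on CHO cells for displacement of a labelled ligand from adenosine receptor A3 (Homo sapiens), read by scintillation counting, tested at 10 uM (a higher number here means more inhibition at the concentration tested (going by the name of the read-out), a lower number less inhibition), compound 3 gives 1%, while compound 1 `CC(C)(C)Cc1csc(N)c1C(=O)c1ccc(Cl)cc1` gives 5% and compound 2 `CC(C)(C)Cc1csc(N)c1C(=O)c1cccc(Cl)c1` gives 8%; all three numbers lie within the usual scatter of one another, so none of them stands apart. Compound 4 `CC(C)(C)Cc1c(-c2cccc(F)c2F)sc(N)c1C(=O)c1ccc(Cl)cc1` differs from compound 3 in one place: 2,3-difluorophenyl in place of pyridin-3-yl on an aromatic carbon. For the measured compounds named here, the only measured step at this position is a number 4 percentage points lower from compound 1 to compound 3 (within the scatter), which stayed within the scatter. Going by the values given here, no measured step exchanges one ring for another there, so the expectation for compound 4 rests on the flat picture so far: a step of a number 2 percentage points higher from compound 3 to compound 4 (within the scatter) is expected, nothing beyond the scatter. Compound 4 is therefore estimated at 3%, within -5% to 12%.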

Compound 4, a percentage reported as inhibition, at one concentration (the size of the read-out at that concentration, not a potency): 1%
Compound 4: the middle estimate sits 2 percentage points above what was measured, within the range that was stated.
By their numbers in this assay, from the lowest: compounds 3, 4, 1 and 2 (each within the scatter of the next).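

In this assay, exchanging the pyridin-3-yl ring for the carbon-only 2,3-difluorophenyl ring gives no change at the digits printed from compound 3 to compound 4 (within the scatter), the first ring-for-ring exchange seen at this position. Putting 2,3-difluorophenyl on the aromatic carbon where compound 1 carries hydrogen gives a number 4 percentage points lower from compound 1 to compound 4 (within the scatter), so both rings shown here leave the read-out inside the scatter. Nothing measured here explains this flat result.

Still open, as far as these compounds go, is whether a different kind of group at this carbon, such as an aminomethyl group or a carboxylic acid, would move the number beyond the scatter.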